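A few compounds are considered here, and "the series" means these few. Any claim that something is new, unique, unknown or untested is made for them only; others in the source may bear on it.

Measured compounds and their values:

compound 1 `COc1ccc(OCC(=O)N2CCN(c3ccc(C(F)(F)F)cc3[C@@H](N)CC(C)C)CC2)cc1` gives 3800 nM
compound 2 `CC(C)C[C@H](N)c1cc(C(F)(F)F)ccc1N1CCN(C(=O)C(C)Cc2ccc(Cl)cc2O)CC1` gives 36 nM
compound 3 `COc1cc(CC(C)C(=O)N2CCN(c3ccc(C(F)(F)F)cc3[C@@H](N)CC(C)C)CC2)ccc1Cl` gives 230 nM

In an assay on HEK293 cells for displacement of a labelled ligand from Melanocortin receptor 4 (Homo sapiens) (a higher number here means a weaker inhibitor, a lower number a stronger inhibitor), compound 1 holds the highest number of the three measured compounds. Both measured steps away from it run downward: a 110-fold lower number from compound 1 to compound 2 (2.02 log units; beyond the scatter) and a 17-fold lower number from compound 1 to compound 3 (1.22 log units; beyond the scatter). Between the two stronger compounds there is also a difference, a 6.4-fold higher number from compound 2 to compound 3 (0.81 log units; beyond the scatter). All three of these steps exchange the whole group on the carbonyl carbon, so they speak to that group as a whole and not to a single substituent on its aromatic ring.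

Compound 4 `CC(C)C[C@H](N)c1cc(C(F)(F)F)ccc1N1CCN(C(=O)COc2ccc([N+](=O)[O-])cc2)CC1` differs from compound 1 in one place only: nitro in place of methoxy on an aromatic carbon. No measured step varies a substituent on the (4-methoxyphenoxy)methyl group while keeping the rest of that group, so nothing shown here bears directly on this change. The expectation is therefore a step of no size beyond the scatter, direction open, with a wide range to reflect the missing precedent: a 1.1-fold lower number from compound 1 to compound 4 (0.04 log units; within the scatter). For compound 4 the estimate in this assay is 3500 nM, expected to fall between 900 nM and 14000 nM.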

Compound 4, inhibition constant: 3100 nM
For compound 4 the middle estimate is 1.1-fold (0.05 log units) above the measured one; measured number inside the range.
By their numbers in this assay, from the lowest: compound 2; then compound 3; then compounds 4 and 1 (each within the scatter of the next).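

In this assay, the change from methoxy to nitro, the first to vary the substituent while keeping the rest of the phenoxy group, stays within the scatter: a 1.2-fold lower number from compound 1 to compound 4 (0.09 log units; within the scatter). At this aromatic carbon, then, these two groups give the same reading, and the gap to the larger carbonyl groups persists with nitro in place: a 13-fold higher number from compound 3 to compound 4 (1.13 log units; beyond the scatter) and an 86-fold higher number from compound 2 to compound 4 (1.94 log units; beyond the scatter). No measurement on these compounds offers an explanation for the flat step.

Methoxy and nitro alone cannot show whether this aromatic carbon tolerates all substitution, so an amine or a carboxylic acid in the same place remains an open test. Also open, on these data alone, is which part of the exchange on the carbonyl carbon carries the large steps, for instance whether a methylene in place of the ether oxygen would do so.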